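This account rests on a few compounds, and the source may have more. Where it says the series, first, only, none or still open, it means among the compounds named here.

Compound 1 `Cc1ccc(S(=O)(=O)c2nc3ccccc3nc2Nc2ccc(N)cc2)cc1`, compound 2 `Cc1ccc(S(=O)(=O)c2nc3ccccc3nc2Nc2cccc(N)c2)cc1` and compound 3 `Nc1ccc(Nc2nc3ccccc3nc2S(=O)(=O)c2ccc(Br)cc2)cc1` were each tested in a functional assay on HL-60 cells (Homo sapiens) for cytotoxicity, read by MTT assay, with a stated time of 72 h; a lower number here means a stronger inhibitor, a higher number a weaker inhibitor. In this assay compound 1 gives 1220 nM, compound 2 gives 1080 nM and compound 3 gives 730 nM. The step of a 1.1-fold lower number from compound 1 to compound 2 (0.05 log units; within the scatter) goes with the change (3-aminophenyl in place of 4-aminophenyl on a nitrogen on an aromatic ring); the step of a 1.7-fold lower number from compound 1 to compound 3 (0.22 log units; within the scatter) goes with the change (bromo in place of methyl on an aromatic carbon).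

Compound 4 `Nc1cccc(Nc2nc3ccccc3nc2S(=O)(=O)c2ccc(Br)cc2)c1` has not yet been measured. It differs from compound 3 by 3-aminophenyl in place of 4-aminophenyl on a nitrogen on an aromatic ring, which is the same change, at the same place, as that from compound 1 to compound 2. The two pairs differ in their shared core by bromo in place of methyl on an aromatic carbon. Because the earlier step of a 1.1-fold lower number from compound 1 to compound 2 (0.05 log units; within the scatter) stayed within the scatter, a step of similar size, a 1.1-fold lower number from compound 3 to compound 4 (0.05 log units; within the scatter), is expected here. Compound 4 is therefore estimated to give 650 nM in this assay, expected to lie between 350 nM and 1200 nM.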

Compound 4, half-maximal inhibitory concentration: 1370 nM
Compound 4: the middle estimate sits 2.1-fold (0.32 log units) below what was measured; the whole stated range lies below it.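

In this assay, 3-aminophenyl in place of 4-aminophenyl gives a 1.9-fold higher number from compound 3 to compound 4 (0.27 log units; within the scatter), and bromo in place of methyl gives a 1.3-fold higher number from compound 2 to compound 4 (0.10 log units; within the scatter). Each of these steps can be set beside its earlier counterpart on another core, and for the change of aminophenyl group the two cannot be told apart: the same change on two cores in this assay, a 1.1-fold lower number (0.05 log units; within the scatter) from compound 1 to compound 2 and a 1.9-fold higher number (0.27 log units; within the scatter) from compound 3 to compound 4, 2.1-fold (0.33 log units) apart, within the scatter of two such steps. The same holds for bromo in place of methyl, so both changes may carry from one core to the other, but this is not proven, since each comparison rests on a single pair of small steps: the same change on two cores in this assay, a 1.7-fold lower number (0.22 log units; within the scatter) from compound 1 to compound 3 and a 1.3-fold higher number (0.10 log units; within the scatter) from compound 2 to compound 4, 2.1-fold (0.33 log units) apart, within the scatter of two such steps.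

As far as these compounds go, it remains open whether a chloro group in place of bromo, or a hydroxyl or carboxylic acid in place of the amino group, would give equally small steps.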